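The compounds below may be only part of what the source reports. "The series", "measured", "known", "first", "only" and "open" are said of these compounds alone.

Measured so far:
compound 1, `O=S(=O)(c1ccc(F)c(Cl)c1)c1cnc2c(F)cccc2c1-c1ccccc1F`: 1.39 mL/min
compound 2, `COc1cccc(S(=O)(=O)c2cnc3cc(F)ccc3c2-c2cccc(Cl)c2)c1`: 2.97 mL/min
compound 3, `COc1cccc(S(=O)(=O)c2cnc3cc(F)ccc3c2-c2cccc(F)c2)c1`: 3.36 mL/min

In an ADME assay on microsomes from liver (Homo sapiens) for metabolic stability, tested at 2.5 uM (a lower number here means slower removal, a higher number faster removal of the compound), compound 3 gives the highest of the three numbers. Compound 2 sits nearest, and the step of a 1.1-fold higher number from compound 2 to compound 3 (0.05 log units; within the scatter) lies within the scatter. Compound 1 lies furthest off, with a gap to compound 3 that is beyond the scatter; compound 1 differs from compound 3 in more than one place, so no single step accounts for that gap.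

Compound 4, `O=S(=O)(c1ccc(F)c(Cl)c1)c1cnc2cc(F)ccc2c1-c1cccc(F)c1`, is the next compound to be measured. It differs from compound 3 by 3-chloro-4-fluorophenyl in place of 3-methoxyphenyl on a sulfonyl sulfur.

Among the compounds with values here, the only step recorded, a 1.1-fold higher number from compound 2 to compound 3 (0.05 log units; within the scatter), changes a different group and is within the scatter, so it bears little on this change. Compound 1 carries the same 3-chloro-4-fluorophenyl on the sulfonyl sulfur and gives 1.39 mL/min, but its other differences from compound 3 leave the attribution open. On that slender basis a lower number is expected for compound 4, with the step of a 1.6-fold lower number from compound 3 to compound 4 (0.20 log units; within the scatter), giving an estimate of 2.1 mL/min with a range from 1.2 mL/min to 3.6 mL/min.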

Compound 4, intrinsic clearance in a liver preparation (reported as CLH), per the amount of preparation that the assay uses: 0.25 mL/min
Estimate against measurement, compound 4: 8.4-fold (0.92 log units) above, outside the stated range (below it).
By their numbers in this assay, from the lowest: compound 4; then compound 1; then compounds 2 and 3 (each within the scatter of the next).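

In this assay, the step of a 13-fold lower number from compound 3 to compound 4 (1.13 log units; beyond the scatter) shows that the group on the sulfonyl sulfur can shift this read-out strongly when the rest of the molecule stays fixed. The change is 3-chloro-4-fluorophenyl in place of 3-methoxyphenyl, and the step is large. The only earlier single-place step, a 1.1-fold higher number from compound 2 to compound 3 (0.05 log units; within the scatter), exchanged fluoro for chloro on an aromatic carbon, so the sulfonyl position is the only place shown where one change moves the number beyond the scatter.

Nothing shown explains the step. From the compounds shown here alone, it remains open whether the loss of methoxy, the chloro or the fluoro carries the step, and how an amine or a carboxylic acid on this ring would read in this assay.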